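Cytotoxicity on normal colon cells: carboxy ring to hydroxypyrrolidine

The source may report more compounds than this note shows. Statements on the series, on what has been measured and on what is new or still open speak of the compounds shown alone.

Measured compounds:
Compound 1 `COc1ccc(/C=C\c2cc(OC)c(OC)c(OC)c2)cc1OCc1ccc(CN[C@H](C(=O)O)[C@H](C)O)cc1`: in an ADME assay on NCM460 cells (Homo sapiens) for cytotoxicity, read by CCK-8 assay, with a stated time of 48 h (a higher number here means a weaker inhibitor, a lower number a stronger inhibitor), compound 1 gives > 50000 nM, which is a limit of the assay and not a number.
Compound 2 `COc1ccc(/C=C\c2cc(OC)c(OC)c(OC)c2)cc1OCc1ccc(CN2CC(C(=O)O)C2)cc1`: in this assay compound 2 gives > 50000 nM, again a limit.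
Compound 3 `COc1ccc(/C=C\c2cc(OC)c(OC)c(OC)c2)cc1OCc1ccc(CN2CCCCC2C(=O)O)cc1`: in this assay compound 3 gives > 50000 nM, again a limit.

Compound 3 therefore stands only at a limit, and all three values shown sit at the same place (the limit of > 50000 nM in this assay, at which 3 of the 3 values shown sit). The steps among them, a step that the two limits leave unreadable from compound 1 to compound 2, a step that the two limits leave unreadable from compound 1 to compound 3 and a step that the two limits leave unreadable from compound 2 to compound 3, cannot be read in size or direction from two limits.

Compound 4 `COc1ccc(/C=C\c2cc(OC)c(OC)c(OC)c2)cc1OCc1ccc(CN2CC[C@H](O)C2)cc1` differs from compound 3 as follows: 3-hydroxypyrrolidin-1-yl in place of 2-carboxypiperidin-1-yl on a saturated chain carbon bound to an aromatic carbon. Within the data shown here, none of the measured steps is readable, so they give no size for the step to compound 4; they show only that changing the carboxy-bearing ring among the three measured compounds has not moved any value off the limit. The expected step of an at least 1.4-fold lower number from compound 3 to compound 4 (0.15 log units; that floor lies within the scatter) is therefore not fixed by data, and a somewhat lower value is allowed since the carboxylic acid leaves. Compound 4 is estimated at 35000 nM, in the range 8000 nM to 60000 nM.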

Compound 4, half-maximal inhibitory concentration: 51000 nM
The estimate for compound 4 lay 1.5-fold (0.16 log units) below the measured number, within the range that was stated.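

No step from compound 1, compound 2 or compound 3 to compound 4 can be read in this assay, as those three compounds give only a limit: the limit of > 50000 nM in this assay, at which 3 of the 4 values shown sit.

On these data alone, whether replacing the group on the saturated chain carbon changes the reading for these four compounds at all remains open.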